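The source may report more compounds than this note shows. Statements on the series, on what has been measured and on what is new or still open speak of the compounds shown alone.

Compound 3 `COc1cc(OC)c(OC)cc1/C=C/COC(=O)/C=C/c1cccc(Br)c1` gives 25% in a functional assay on the whole organism (strain Kunming) with Mus musculus as the target, with a stated time of 0.5 h, at a dose of 300 mg/kg by the intraperitoneal route (on this read-out higher numbers stand for a weaker effect at the one dose given and lower numbers for a stronger effect), level with compound 2 `COc1cc(OC)c(OC)cc1/C=C/COC(=O)/C=C/c1ccc(Br)cc1`, which gives 25%; together these are the highest numbers among the three measured compounds. Compound 1 `COc1cc(OC)c(OC)cc1/C=C/COC(=O)/C=C/c1ccc(OC)c(OC)c1` gives 0%, the lowest number. Compound 4 `COc1cccc(/C=C/C(=O)OC/C=C/c2cc(OC)c(OC)cc2OC)c1` differs from compound 3 by methoxy in place of bromo on an aromatic carbon. Within the data shown here, two measured steps bear on this change: the step of a number 25 percentage points higher from compound 1 to compound 3 (beyond the scatter), which exchanged the whole dimethoxy-bearing ring for the bromo-bearing one, and the step of no change at the digits printed from compound 2 to compound 3 (within the scatter). Replacing bromo by methoxy partly reverses the former, so a number lower than that of compound 3 is expected. Only one of the two methoxy groups returns, so the expected step is smaller than the full step. The estimated step is a number 15 percentage points lower from compound 3 to compound 4 (beyond the scatter), giving compound 4 an expected value of 10%, within a range from 0% to 30%.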

Compound 4, a percentage reported as activity, at one dose (the size of the read-out at that dose, not a potency): 50%
Compound 4: middle estimate off by 40 percentage points, on the low side, and the stated range ends below it.
By their numbers in this assay, from the lowest: compound 1; then compounds 2 and 3 (each within the scatter of the next); then compound 4.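

In this assay methoxy in place of bromo, meta to a large group, does not bring the number back toward that of compound 1: the change runs a number 25 percentage points higher from compound 3 to compound 4 (beyond the scatter) and a number 25 percentage points higher from compound 2 to compound 4 (beyond the scatter) when set against the two bromo compounds. Hydrogen in place of methoxy gives a number 50 percentage points higher from compound 1 to compound 4 (beyond the scatter) as the largest step here, so a single methoxy at this place does not reproduce the number of the 3,4-dimethoxyphenyl compound. Nothing measured here gives a reason for this.

On these data alone, whether 4-methoxyphenyl, or a hydroxy group or an amine on this ring, would give a number nearer that of compound 1 or that of compound 4 remains open.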